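From propanoyl to acetyl on compound 1

The compounds below may be only part of what the source reports. "The series", "measured", "known", "first", "only" and "open" are said of these compounds alone.

Measured in a functional assay on SK-MEL-28 cells (Homo sapiens) for inhibition, read by MTT assay, with a stated time of 72 h; on this read-out lower numbers stand for stronger inhibition and higher numbers for weaker inhibition:
- Compound 1 `CCC(=O)O[C@@H](/C(C)=C/[C@@H](C)c1oc(CC)c(C)c(=O)c1C)[C@H](C)[C@@H](OC(=O)CC(C)C)[C@@H](C)c1oc([C@@H](C)[C@@H](O)CC)c(C)c(=O)c1C`: 25000 nM
- Compound 2 `CCC(=O)[C@H](C)c1oc([C@H](C)[C@@H]2O[C@](O)([C@@H](C)c3oc(CC)c(C)c(=O)c3C)[C@@H](C)[C@@H](O)[C@@H]2C)c(C)c(=O)c1C`: > 100000 nM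
- Compound 3 `CCC(=O)[C@H](C)c1oc([C@H](C)[C@@H]2O[C@](O)([C@@H](C)c3oc(CC)c(C)c(=O)c3C)[C@@H](C)[C@@H](OC(=O)CC(C)C)[C@@H]2C)c(C)c(=O)c1C`: 23000 nM

Compound 2 has the entry > 100000 nM, which is a limit and not a number. That leaves two true numbers, and compound 1 at 25000 nM lies within the scatter of compound 3 at 23000 nM.

The next compound is compound 4 `CCc1oc([C@H](C)/C=C(\C)[C@H](OC(C)=O)[C@H](C)[C@@H](OC(=O)CC(C)C)[C@@H](C)c2oc([C@@H](C)[C@@H](O)CC)c(C)c(=O)c2C)c(C)c(=O)c1C`, which has not yet been measured. Its difference from compound 1 is hydrogen in place of methyl on a saturated chain carbon bound to a carbonyl carbon. In words, this is hydrogen in place of methyl on a saturated chain carbon bound to a carbonyl carbon, which turns propanoyloxy into acetoxy.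

Among the compounds with values here, only one measured step is available, and it bears on this change only loosely: an at least 4.3-fold lower number from compound 2 to compound 3 (0.63 log units; beyond the scatter). That step adds a whole isobutylcarbonyl in place of hydrogen on an oxygen on a saturated carbon, and compound 4 keeps that group. The change from compound 1 is far smaller and leaves an ester in place, so no shift beyond the scatter is expected in this assay. The expected change is no change at the digits printed from compound 1 to compound 4 (within the scatter). Compound 4 is estimated at 25000 nM, with an expected range from 10000 nM to 60000 nM.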

Compound 4, half-maximal inhibitory concentration: 25000 nM
The estimate for compound 4 equals the measured number at the digits printed; the measured number falls inside the stated range.
By their numbers in this assay, from the lowest: compounds 3, 1 and 4 (each within the scatter of the next). At a limit, above all of these: compound 2.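

The trim from propanoyloxy to acetoxy gives no change at the digits printed from compound 1 to compound 4 (within the scatter) in this assay, so removing the methyl on a saturated chain carbon bound to a carbonyl carbon leaves no readable mark on this read-out. Within the data shown here, the only earlier step, an at least 4.3-fold lower number from compound 2 to compound 3 (0.63 log units; beyond the scatter), concerned a different change, the placing of an isobutylcarbonyl on an oxygen, and it said nothing about this ester; the new pair adds that the end of the propanoyl chain can be cut back by one carbon with the two numbers staying within the scatter of each other. Nothing given here offers a reason for this outcome.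

On these data alone, the pair covers only propanoyl and acetyl, so it remains open whether a longer chain such as butanoyl, or a larger acyl group such as benzoyl, would read the same in this assay. As far as these compounds go, it also remains open what a free hydroxyl, or an amine, would do in place of this ester, and so whether the ester itself counts for anything here or only its length does not.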